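The source may hold more compounds than are shown below. What is called first, only, known or untested is meant among the compounds shown, and "the series" means these compounds.

Working notes on the series.

Within the data shown here, compound 2 (`O=C(Nc1ccc(NCc2cnccc2Cl)cc1Cl)c1cc(Cl)ccc1O`) stands highest of the two numbers so far in an ADME assay on A549 cells (Homo sapiens) for cytotoxicity, read by resazurin assay, with a stated time of 48 h (on this read-out higher numbers stand for lower toxicity in this test and lower numbers for higher toxicity in this test), giving 126000 nM. Among the measured compounds shown here, the nearest neighbour is compound 1 (`O=C(Nc1ccc(NCc2ccc(Br)cc2)cc1Cl)c1cc(Cl)ccc1O`), which in this assay gives 40900 nM; the one measured step, a 3.1-fold higher number from compound 1 to compound 2 (0.49 log units; beyond the scatter), exchanges one ring for another at the saturated chain carbon bound to a nitrogen on an aromatic ring.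

Compound 3 (`O=C(Nc1ccc(NCCCO)cc1Cl)c1cc(Cl)ccc1O`) is the next member to be measured. It differs from compound 2 as follows: 2-hydroxyethyl in place of 4-chloropyridin-3-yl on a saturated chain carbon bound to a nitrogen on an aromatic ring. For the measured compounds named here, this change removes the ring at that position altogether and puts a short chain there, so the only step in hand, which swapped one aromatic ring for another and came out modest, bears on it only loosely: it shows that this position tolerates exchange without a large swing, but gives no direction for a ring-to-chain replacement.

Compound 3 is therefore expected to sit near compound 2, the estimated step of a 1.1-fold lower number from compound 2 to compound 3 (0.06 log units; within the scatter) staying within or just beyond the scatter, in no firm direction. The estimate for compound 3 in this assay is 110000 nM, with a range from 45000 nM to 270000 nM.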

Compound 3, half-maximal cytotoxic concentration: 106000 nM
The estimate for compound 3 lay 1.0-fold (0.02 log units) above the measured number; measured number inside the range.
By their numbers in this assay, from the lowest: compound 1; then compounds 3 and 2 (each within the scatter of the next).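

The ring at this position can give way to an open chain with no change beyond the scatter in this assay: 2-hydroxyethyl in place of 4-chloropyridin-3-yl gives a 1.2-fold lower number from compound 2 to compound 3 (0.08 log units; within the scatter), so an aromatic ring here is not required for a number at this level. The same chain in place of 4-bromophenyl gives a 2.6-fold higher number from compound 1 to compound 3 (0.41 log units; beyond the scatter), which, together with a 3.1-fold higher number from compound 1 to compound 2 (0.49 log units; beyond the scatter), leaves compound 1 as the only one of the three set apart, with compound 2 and compound 3 level within the scatter and both clear of it. No measurement on hand explains this difference.

Among these compounds, with only three compounds, it remains open whether the lower number belongs to the 4-bromophenyl group as a whole or to some part of it, since the step to the 4-chloropyridin-3-yl group changes both the ring and the halogen. From the compounds shown here alone, it also remains open whether the level shared by compound 2 and compound 3 holds for a chain ending in an amine or a carboxylic acid, or for a longer chain, at this same saturated chain carbon.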